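The source may hold more compounds than are shown below. What is called first, only, known or untested is meant among the compounds shown, and "the series" means these compounds.

Three compounds have been measured in an assay for binding affinity to dual specificity mitogen-activated protein kinase kinase 4 (Homo sapiens), read by KINOMEscan, tested at 100 nM; a lower number here means a stronger effect, a higher number a weaker effect of the compound at the concentration tested:

Compound 1, `CCCS(=O)(=O)Nc1ccc(F)c(C(=O)c2n[nH]c3ncc(-c4cccc(F)c4)cc23)c1F`, gives 8.2%.
Compound 2, `CCCS(=O)(=O)Nc1ccc(F)c(C(=O)c2n[nH]c3ncc(-c4ccc(F)cc4)cc23)c1F`, gives 2.1%.
Compound 3, `CCCS(=O)(=O)Nc1ccc(F)c(C(=O)c2n[nH]c3ncc(-c4ccc(C)cc4)cc23)c1F`, gives 5.4%.

All three share the same core and differ only in the aromatic ring attached to it. Compound 3 stands second highest of these three numbers; its neighbours are close on both sides, as the steps of a number 2.8 percentage points lower from compound 1 to compound 3 (within the scatter) and a number 3.3 percentage points higher from compound 2 to compound 3 (within the scatter) show, and the step of a number 6.1 percentage points lower from compound 1 to compound 2 (within the scatter) is of the same kind. None of these three changes at the attached ring moved the read-out beyond the usual scatter.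

Compound 4, `CCCS(=O)(=O)Nc1ccc(F)c(C(=O)c2n[nH]c3ncc(-c4cccc(O)c4)cc23)c1F`, is not yet measured. It differs from compound 3 in one place: 3-hydroxyphenyl in place of 4-methylphenyl on an aromatic carbon. The three measured steps all bear on this change, since each swaps one group for another on the same aromatic carbon, and each was within the scatter. On that basis no step beyond the scatter is expected, a number 0.6 percentage points higher from compound 3 to compound 4 (within the scatter). Compound 4 is therefore estimated at 6%, with a range from 1% to 20%.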

Compound 4, a percentage reported as activity, at one concentration (the size of the read-out at that concentration, not a potency): 2.2%
For compound 4 the middle estimate is 3.8 percentage points above the measured one; measured number inside the range.
By their numbers in this assay, from the lowest: compounds 2, 4, 3 and 1 (each within the scatter of the next).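

Swapping in 3-hydroxyphenyl puts a hydrogen-bond donor and a hydrogen-bond acceptor on this aromatic carbon for the first time, yet the steps remain small: a number 3.2 percentage points lower from compound 3 to compound 4 (within the scatter), a number 0.1 percentage points higher from compound 2 to compound 4 (within the scatter) and a number 6 percentage points lower from compound 1 to compound 4 (within the scatter). In this assay, this position has therefore taken a ring bearing hydroxy as well as rings bearing fluoro or methyl, with no step among these four compounds beyond the scatter. No measurement is available that could explain this outcome.

Still open, going by these compounds, is whether a ring carrying an amine or a carboxylic acid at this position would move the number beyond the scatter. On these data alone, it is also open whether 4-hydroxyphenyl would give a number close to that of 3-hydroxyphenyl.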